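The source may report more compounds than this note shows. Statements on the series, on what has been measured and on what is new or still open speak of the compounds shown alone.

Measured compounds, with their numbers in an assay for inhibition of Fatty-acid amide hydrolase 1 (Rattus norvegicus), using a Dixon plot; on this read-out higher numbers stand for weaker inhibition and lower numbers for stronger inhibition:

Compound 1 `COCOCc1ccc(-c2cnc(C(=O)CCCCCCc3ccccc3)o2)nc1` gives 10.1 nM.
Compound 2 `C[S+]([O-])/C=C/c1ccc(-c2cnc(C(=O)CCCCCCc3ccccc3)o2)nc1` gives 3 nM.
Compound 3 `O=C(O)CCCCc1cnc(C(=O)CCCCCCc2ccccc2)o1` gives 23.8 nM.

Compound 3 stands highest of the three numbers in this assay, that is, it is the weakest inhibitor of the set: compound 1 sits closer to it, compound 2 furthest away. Within the data shown here, the only step between measured compounds that differ in one place is a 3.4-fold lower number from compound 1 to compound 2 (0.53 log units; beyond the scatter), a change on an aromatic carbon of the shared core.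

Compound 4 `CSCCCCCc1cnc(C(=O)CCCCCCc2ccccc2)o1` is not yet measured. It differs from compound 3 in one place: (methylsulfanyl)methyl in place of carboxy on a saturated chain carbon, four bonds along the chain from an aromatic carbon. The step from compound 1 to compound 2 also brings a sulfur-bearing group in, but at a different place on the core and in exchange for a different group, so it bears on the present change only loosely. Among the measured compounds shown here, no measured step removes a carboxy group from this chain. The expectation therefore rests chiefly on the value of compound 3 itself, with the loose hint from the step to compound 2 that a sulfur-bearing group need not hurt. For compound 4 a step of a 2.4-fold lower number from compound 3 to compound 4 (0.38 log units; beyond the scatter) in this assay is expected, toward a lower number. Compound 4 is estimated at 10 nM, within 3 nM to 35 nM.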

Compound 4, inhibition constant: 8.1 nM
Compound 4: the middle estimate sits 1.2-fold (0.09 log units) above what was measured, and the stated range covers the measured number.
By their numbers in this assay, from the lowest: compound 2; then compounds 4 and 1 (each within the scatter of the next); then compound 3.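

In this assay, the exchange of carboxy for (methylsulfanyl)methyl on a saturated chain carbon, four bonds along the chain from an aromatic carbon, gives a 2.9-fold lower number from compound 3 to compound 4 (0.47 log units; beyond the scatter) and is a modest gain. Among these compounds, this is the first step read at this place on the chain, and it shows that inhibition does not depend on the carboxy group or its hydrogen-bond donor, since the entering group has no such donor. No measurement at hand accounts for the step, so what in the exchange carries it stays unassigned.

Open, from the compounds shown here alone, is whether the sulfur contributes at all, or whether a plain alkyl group or a methyl ether at this place would do the same. Also open, going by these compounds, is how a longer chain or an amine would fare here.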